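A Larger Group on the Sulfur of Compound 3

The source may hold more compounds than are shown below. What is called first, only, known or untested is meant among the compounds shown, and "the series" means these compounds.

Compound 3 `C#CSc1nc2nc(C)cc(N3CC[C@@H](C)[C@@H](N(C)c4ncnc5[nH]ccc45)C3)n2n1` gives the highest of the three numbers in a functional assay on HGC-27 cells (Homo sapiens) for inhibition, read by MTT assay, with a stated time of 72 h (a higher number here means a weaker inhibitor, a lower number a stronger inhibitor), at 35100 nM. Compound 1 `Cc1cc(N2CC[C@@H](C)[C@@H](N(C)c3ncnc4[nH]ccc34)C2)n2ncnc2n1` gives 11300 nM and compound 2 `CCCSc1nc2nc(C)cc(N3CC[C@@H](C)[C@@H](N(C)c4ncnc5[nH]ccc45)C3)n2n1` gives 20900 nM. Compound 4 `Cc1cc(N2CC[C@@H](C)[C@@H](N(C)c3ncnc4[nH]ccc34)C2)n2nc(SCc3csc4ccc(Cl)cc34)nc2n1` differs from compound 3 in one place: (5-chloro-1-benzothiophen-3-yl)methyl in place of ethynyl on a sulfur. The measured steps that bear on this change are those at the same sulfur and its attachment point: a 1.7-fold higher number from compound 2 to compound 3 (0.23 log units; within the scatter), a 1.8-fold higher number from compound 1 to compound 2 (0.27 log units; within the scatter) and a 3.1-fold higher number from compound 1 to compound 3 (0.49 log units; beyond the scatter). None of these goes beyond a modest size, so the expected step of a 1.4-fold lower number from compound 3 to compound 4 (0.15 log units; within the scatter) is also small, without a clear direction beyond the scatter. Compound 4 is therefore expected to give about 25000 nM, within a range from 8000 nM to 80000 nM.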

Compound 4, half-maximal inhibitory concentration: > 100000 nM
Compound 4: no number, only a limit; the forecaster's own chance of this, stated with the estimate: 10%; middle value at least 4.0-fold (0.60 log units) away from the limit.
By their numbers in this assay, from the lowest: compounds 1, 2 and 3 (each within the scatter of the next, the first and the last beyond it). At a limit, above all of these: compound 4.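

Compound 4 gives only a limit in this assay, > 100000 nM. The steps to it read an at least 2.8-fold higher number from compound 3 to compound 4 (0.45 log units; beyond the scatter), an at least 4.7-fold higher number from compound 2 to compound 4 (0.67 log units; beyond the scatter) and an at least 8.8-fold higher number from compound 1 to compound 4 (0.94 log units; beyond the scatter). Propyl and ethynyl on this sulfur had given steps of modest size at most, so (5-chloro-1-benzothiophen-3-yl)methyl is the first group to show that a change here can leave the compound clearly weaker than all the others shown.

Going by these compounds, whether the chlorine or the benzothiophene carries this step stays open, as does what a benzyl group or an aminoethyl chain on the same sulfur would give.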